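From 4-chlorobenzyl to 4-methylphenyl on a ring nitrogen

The compounds below may be only part of what the source reports. "The series", "measured", "known", "first", "only" and "open" are said of these compounds alone.

Compound 1 `COC(=O)CC/C(C)=C/Cc1c(OC)c(C)c2c(c1OCC#CCN1CCN(c3ccc(C#N)cc3)CC1)C(=O)OC2` gives > 50000 nM (a limit)
Compound 2 `COC(=O)CC/C(C)=C/Cc1c(OC)c(C)c2c(c1OCC#CCN1CCN(Cc3ccc(Cl)cc3)CC1)C(=O)OC2` gives > 50000 nM (a limit)

Both entries come from a functional assay on FaDu cells (Homo sapiens) for inhibition, read by sulforhodamine B assay (on this read-out higher numbers stand for weaker inhibition and lower numbers for stronger inhibition), and neither is an exact number. Compound 2 gives > 50000 nM in this assay, which is only a limit. The measurements so far show the limit of > 50000 nM in this assay, at which 2 of the 2 values shown sit, and nothing finer. Compound 3 `COC(=O)CC/C(C)=C/Cc1c(OC)c(C)c2c(c1OCC#CCN1CCN(c3ccc(C)cc3)CC1)C(=O)OC2` differs from compound 2 by one group: 4-methylphenyl in place of 4-chlorobenzyl on an amine nitrogen in a ring, with 4-methylphenyl in place of 4-chlorobenzyl on an amine nitrogen in a ring. Within the data shown here, the only measured step, a step that the two limits leave unreadable from compound 1 to compound 2, has no readable size, so no change beyond the scatter is expected in this assay, in either direction. The estimated a number no higher from compound 2 to compound 3 (the limit leaves the size open) is therefore expected to be small. For compound 3 the estimate is 50000 nM, with an expected range from 25000 nM to 100000 nM, and another limit is the likeliest result.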

Compound 3, half-maximal inhibitory concentration: > 50000 nM
Compound 3: no number, only a limit; the forecaster's own chance of this, stated with the estimate: 80%; the middle value lies on the limit itself.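

Among these compounds, compound 3 gives > 50000 nM in this assay, again only a limit, so no step among compound 1, compound 2 and compound 3 can be read: the limit of > 50000 nM in this assay, at which 3 of the 3 values shown sit. The compounds shown leave open whether any of these groups on the ring nitrogen changes inhibition in this assay.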